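Changing the aryl group on the amine of compound 3

The source may hold more compounds than are shown below. What is called first, only, known or untested is meant among the compounds shown, and "the series" means these compounds.

The measured compounds:
Compound 1 `C[C@@H](NC(=O)OC(C)(C)C)C(=O)Nc1ccc2ncnc(Nc3ccc(F)c(Cl)c3)c2c1`: in a functional assay on HepG2 cells (Homo sapiens) for antiproliferative activity, read by sulforhodamine B assay, with a stated time of 72 h (a higher number here means a weaker inhibitor, a lower number a stronger inhibitor), compound 1 gives > 50000 nM, a limit of the assay.
Compound 2 `CC(C)[C@@H](NC(=O)OC(C)(C)C)C(=O)Nc1ccc2ncnc(Nc3ccc(F)c(Cl)c3)c2c1`: compound 2 gives > 50000 nM, also a limit.
Compound 3 `CC(C)C[C@@H](NC(=O)OC(C)(C)C)C(=O)Nc1ccc2ncnc(Nc3ccc(F)c(Cl)c3)c2c1`: compound 3 gives 13800 nM.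

Within the data shown here, compound 3 is thus the only compound with a number; the other two sit at the limit of > 50000 nM in this assay, at which 2 of the 3 values shown sit. The steps of an at least 3.6-fold lower number from compound 1 to compound 3 (0.55 log units; beyond the scatter) and an at least 3.6-fold lower number from compound 2 to compound 3 (0.55 log units; beyond the scatter) concern the side chain, and a step that the two limits leave unreadable from compound 1 to compound 2 is unreadable. Compound 4 `CC(C)C[C@@H](NC(=O)OC(C)(C)C)C(=O)Nc1ccc2ncnc(Nc3cccc(Br)c3)c2c1` differs from compound 3 by 3-bromophenyl in place of 3-chloro-4-fluorophenyl on a nitrogen on an aromatic ring. Among the measured compounds shown here, none of the measured steps touches this part of the structure, so there is no basis for expecting a shift beyond the scatter. The step of a 1.0-fold higher number from compound 3 to compound 4 (0.01 log units; within the scatter) is expected to be essentially flat. Compound 4 is therefore estimated at 14000 nM, in the range 5000 nM to 45000 nM.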

Compound 4, half-maximal inhibitory concentration: 25000 nM
Estimate against measurement, compound 4: 1.8-fold (0.25 log units) below; the measured number falls inside the stated range.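

In this assay, among these compounds, the earlier steps all concerned the side chain; this is the first readable step at the aryl group on the nitrogen. Putting 3-bromophenyl in place of 3-chloro-4-fluorophenyl gives a 1.8-fold higher number from compound 3 to compound 4 (0.26 log units; within the scatter) and so leaves the two compounds indistinguishable here. This position therefore accepts this one swap, in which the fluorine goes and bromine replaces chlorine, without a readable change.

As far as these compounds go, whether a plain phenyl, a 3-methoxyphenyl or a 3-aminophenyl would behave alike remains open. Nothing measured here explains why this swap changes so little.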